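The compounds below may be only part of what the source reports. "The series", "measured", "known", "first", "only" and "open" are said of these compounds alone.

Two compounds share a core in which a propanoic acid chain is linked through an aromatic system to an amide that carries an aromatic ring. Compound 1 `O=C(O)CCc1nnc(C(=O)Nc2cccc(-c3ccco3)c2)s1` has a furan ring attached to that amide-bearing ring, while compound 2 `O=C(O)CCc1ccc(OCc2nnc(C(=O)Nc3ccccc3)s2)cc1` keeps a plain phenyl on the amide and places the acid chain on a separate ring joined through an ether. In a functional assay on CHO cells for agonist activity at Free fatty acid receptor 1 (Homo sapiens), read by calcium flux (on this read-out higher numbers stand for an effect only at larger amounts of compound and lower numbers for an effect already at smaller amounts), compound 1 gives 1640 nM and compound 2 gives 1060 nM; the two numbers lie within the scatter of each other, so neither can be called the more potent of the pair. Compound 3 `O=C(O)CCc1ccc(OCc2nnc(C(=O)Nc3ccc(Cl)cc3)s2)cc1` differs from compound 2 in one place: chloro in place of hydrogen on an aromatic carbon. Among the compounds with values here, no measured pair shows what this kind of change does here, so the expectation rests on the size of the step alone. A single chloro added at this place is expected to shift the number by a 1.5-fold lower number from compound 2 to compound 3 (0.18 log units; within the scatter), a step that is expected to fall within the usual scatter, and compound 3 is therefore estimated to give 700 nM, in a range from 250 nM to 2000 nM.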

Compound 3, half-maximal effective concentration: 3690 nM
Beside the measured number, compound 3's estimate is 5.3-fold (0.72 log units) below it, outside the stated range (above it).
By their numbers in this assay, from the lowest: compounds 2 and 1 (each within the scatter of the next); then compound 3.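

The change from phenyl to 4-chlorophenyl brings a 3.5-fold higher number from compound 2 to compound 3 (0.54 log units; beyond the scatter) in this assay, so more of the compound is needed for the same effect. Within the data shown here, this is the first change in the set that alters one place only, and it shows that this aromatic carbon, para to a large group, is not indifferent: a single chlorine atom in place of a hydrogen is enough to move the number beyond the usual scatter, and the step runs towards weaker agonist activity rather than stronger. Nothing among the data shown accounts for the direction or size of this step, so the result records what happens at this position without explaining it.

The compounds shown leave open whether the rise is particular to chloro or whether a fluoro, methyl or methoxy group at this same carbon would move the number as far. They also leave open whether chloro on another carbon of this ring would bring a similar step, and whether the same change would act alike on the core of compound 1.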